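The compounds below may be only part of what the source reports. "The series", "measured", "known", "first", "only" and "open" are said of these compounds alone.

Compound 1 `NC(=O)N1CCN(C(=S)SCc2cn(Cc3ccccc3F)nn2)CC1` — in a functional assay on SMMC-7721 cells (Homo sapiens) for cytotoxicity, read by MTT assay, with a stated time of 72 h (a lower number here means a stronger inhibitor, a higher number a weaker inhibitor), compound 1 gives > 128000 nM, which is a limit of the assay rather than a number.
Compound 2 `CC(C)NC(=O)N1CCN(C(=S)SCc2cn(Cc3ccccc3F)nn2)CC1` — in this assay compound 2 gives 7130 nM.
Compound 3 `CCN(C)C(=O)N1CCN(C(=S)SCc2cn(Cc3ccccc3F)nn2)CC1` — in this assay compound 3 gives 19700 nM.

Of the two numbers recorded in this assay, compound 3 stands highest, with compound 2 as its nearest neighbour, a 2.8-fold higher number from compound 2 to compound 3 (0.44 log units; beyond the scatter). The third entry is the limit of > 128000 nM in this assay, at which 1 of the 3 values shown sits.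

Compound 4 `CC(C)(C)NC(=O)N1CCN(C(=S)SCc2cn(Cc3ccccc3F)nn2)CC1` differs from compound 3 in one place: (tert-butyl)amino in place of ethyl(methyl)amino on a carbonyl carbon. The same carbonyl substituent has been varied twice among the measured compounds: once an at least 17-fold lower number from compound 1 to compound 2 (1.25 log units; beyond the scatter), and once a 2.8-fold higher number from compound 2 to compound 3 (0.44 log units; beyond the scatter). Both steps show that this position moves the readout in this assay well beyond the scatter, and that a branched alkylamino group gave the lowest number seen. The tert-butylamino group entering in compound 4 is closest in kind to the isopropylamino group of compound 2, which in this assay gives 7130 nM. Compound 4 is therefore expected to show a 2.6-fold lower number from compound 3 to compound 4 (0.42 log units; beyond the scatter), a move back toward that figure. The estimate for compound 4 in this assay is 7500 nM, with a likely range from 2500 nM to 25000 nM.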

Compound 4, half-maximal inhibitory concentration: > 128000 nM
Compound 4 gave a limit, no number; the forecaster's own chance of this, stated with the estimate: 5%; at least 17-fold (1.23 log units) between middle value and limit.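

In this assay the carbonyl substituent does not simply tolerate branched alkylamino groups: one added methyl on the saturated chain carbon is enough to lose the figure held by compound 2 (an at least 17-fold higher number from compound 2 to compound 4 (1.25 log units; beyond the scatter)). The change from ethyl(methyl)amino to (tert-butyl)amino also brings in a hydrogen-bond donor and goes the wrong way (an at least 6.4-fold higher number from compound 3 to compound 4 (0.81 log units; beyond the scatter)), so compound 3, without the amide hydrogen, keeps a readable number while compound 4, which has it, does not, and the amide hydrogen alone does not decide the outcome, as compound 2 also carries it and gives the lowest number. Compound 4 gives a limit and no number, as does compound 1, and the step between these two cannot be read: the limit of > 128000 nM in this assay, at which 2 of the 4 values shown sit.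

The compounds shown leave open whether a straight chain such as n-butylamino, or a ring such as cyclopropylamino, on the carbonyl carbon would stay near compound 2 or fall to the limit. They also leave open whether diethylamino, which like ethyl(methyl)amino has no amide hydrogen, would keep a readable number.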